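Methyl shift on the pyrazole: expected clearance in mouse microsomes

This account rests on a few compounds, and the source may have more. Where it says the series, first, only, none or still open, it means among the compounds named here.

Compound 1 `Cc1[nH]ncc1-c1cncc(-c2ccc(C(N)=O)c(OC(C)C)c2)c1` gives 251 mL.min-1.g-1
Compound 2 `Cc1n[nH]c(C)c1-c1cncc(-c2ccc(C(N)=O)c(OC(C)C)c2)c1` gives 62 mL.min-1.g-1

In an ADME assay on microsomes from liver (Mus musculus) for pharmacokinetics (a higher number here means faster removal of the compound, a lower number slower removal), compound 2 stands lowest of the two measured compounds. Going by the values given here, the only measured step, a 4.0-fold lower number from compound 1 to compound 2 (0.61 log units; beyond the scatter), put a methyl in place of hydrogen on an aromatic carbon. Compound 3 `Cc1c(-c2cncc(-c3ccc(C(N)=O)c(OC(C)C)c3)c2)cnn1C` differs from compound 2 as follows: 1,5-dimethyl-1H-pyrazol-4-yl in place of 3,5-dimethyl-1H-pyrazol-4-yl on an aromatic carbon. Among the compounds with values here, this takes a methyl off an aromatic carbon and puts it on nitrogen, a case no measured step covers. Going by a 4.0-fold lower number from compound 1 to compound 2 (0.61 log units; beyond the scatter), a partial reversal is expected, a 2.1-fold higher number from compound 2 to compound 3 (0.32 log units; beyond the scatter), with wide uncertainty. For compound 3 the estimated value is 130 mL.min-1.g-1, with an expected range of 55 mL.min-1.g-1 to 300 mL.min-1.g-1.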

Compound 3, intrinsic clearance in microsomes: 25.1 mL.min-1.g-1
Estimate against measurement, compound 3: 5.2-fold (0.71 log units) above; measured number outside the range, below it.
By their numbers in this assay, from the lowest: compound 3; then compound 2; then compound 1.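

In this assay, moving the methyl from carbon to nitrogen does not reverse the earlier gain but extends it (a 2.5-fold lower number from compound 2 to compound 3 (0.39 log units; beyond the scatter)). With 1,5-dimethyl-1H-pyrazol-4-yl, the number falls further than with 3,5-dimethyl-1H-pyrazol-4-yl, and methyl on the aromatic nitrogen gives the step (a 10-fold lower number from compound 1 to compound 3 (1.00 log units; beyond the scatter)), so the place of the methyl matters as well as its presence. Nothing at hand explains this difference between the two isomers. Open, going by these compounds, is whether an ethyl or 2-methoxyethyl chain on that nitrogen keeps the low number. Also open, on these data alone, is how a nitrogen methyl behaves without the carbon methyl.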